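The source may hold more compounds than are shown below. What is called first, only, known or untested is meant among the compounds shown, and "the series" means these compounds.

Compound 1 `C=C1C(=O)[C@]23C[C@@]1(O)CC[C@H]2c1ccc(OS(=O)(=O)c2ccc(C)cc2)c(C)c1[C@@H]3Cn1cc(-c2ccc(F)cc2)nn1`: 1950 nM
Compound 2 `C=C1C(=O)[C@]23C[C@@]1(O)CC[C@H]2c1ccc(O)c(C)c1[C@@H]3Cn1cc(-c2ccccn2)nn1`: 1570 nM
Compound 3 `C=C1C(=O)[C@]23C[C@@]1(O)CC[C@H]2c1ccc(OS(=O)(=O)c2ccc(C)cc2)c(C)c1[C@@H]3Cn1cc(-c2ccc(OC)cc2)nn1`: 1470 nM

All three compounds were tested in a functional assay on A549 cells (Homo sapiens) for cytotoxicity, read by MTT assay, with a stated time of 4 days; on this read-out higher numbers stand for weaker inhibition and lower numbers for stronger inhibition. Among these three numbers, compound 3 gives the lowest, but its gaps to compound 2 and to compound 1 both lie within the scatter, so none of the three can be called stronger or weaker than another on what has been measured.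

Compound 4 `C=C1C(=O)[C@]23C[C@@]1(O)CC[C@H]2c1ccc(OS(=O)(=O)c2ccc(C)cc2)c(C)c1[C@@H]3Cn1cc(-c2ccccn2)nn1` has not yet been measured. Relative to compound 3 it carries pyridin-2-yl in place of 4-methoxyphenyl on an aromatic carbon. Going by the values given here, one measured step bears on this kind of change, an exchange of one aromatic group for another at the same position on the shared core: a 1.3-fold lower number from compound 1 to compound 3 (0.12 log units; within the scatter), which barely moved the number. Compound 2 carries the same pyridin-2-yl group as compound 4 but differs from it elsewhere, and its value sits close to that of compound 3. Taken together, no step beyond the scatter is expected in this assay; the expected step is a 1.1-fold higher number from compound 3 to compound 4 (0.04 log units; within the scatter). Compound 4 is therefore estimated at 1600 nM, within a range from 800 nM to 3200 nM.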

Compound 4, half-maximal inhibitory concentration: 2310 nM
Compound 4: middle estimate off by 1.4-fold (0.16 log units), on the low side, within the range that was stated.
By their numbers in this assay, from the lowest: compounds 3, 2, 1 and 4 (each within the scatter of the next).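

In this assay, pyridin-2-yl on an aromatic carbon of the five-membered aromatic ring leaves the number within the scatter against two different groups: 4-methoxyphenyl gives way to it with a 1.6-fold higher number from compound 3 to compound 4 (0.20 log units; within the scatter) and 4-fluorophenyl with a 1.2-fold higher number from compound 1 to compound 4 (0.07 log units; within the scatter). With pyridin-2-yl held fixed, a second place on the shared core can also be read, as (4-methylphenyl)sulfonyl in place of hydrogen on the oxygen gives a 1.5-fold higher number from compound 2 to compound 4 (0.17 log units; within the scatter). No measurement at hand explains why these steps are so small.

Every group shown on the five-membered ring is a six-membered aromatic ring, so it remains open whether an amine, a carboxylic acid or a longer alkyl chain there would move the number beyond the scatter. The oxygen likewise leaves open what a smaller group, such as methyl or acetyl, would do.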